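The source may hold more compounds than are shown below. What is called first, only, known or untested is meant among the compounds shown, and "the series" means these compounds.

Series of compounds sharing one core, each varied at the group on a sulfur attached to an aromatic carbon. Compound 1 `CC(C)c1n[nH]c2c(NCc3ccc(-c4ccccn4)cc3)nc(SCC(N)CN)nc12` gives 480 nM in a functional assay on HT cells (Homo sapiens) for antiproliferative activity, read by fluorescence, with a stated time of 72 h; a higher number here means a weaker inhibitor of growth, a lower number a stronger inhibitor of growth. Compound 2 `CC(C)c1n[nH]c2c(NCc3ccc(-c4ccccn4)cc3)nc(SCC(C)(C)O)nc12` gives 507 nM, and compound 3 `CC(C)c1n[nH]c2c(NCc3ccc(-c4ccccn4)cc3)nc(SC3CCCCC3N)nc12` gives 139 nM; compound 3 thus has the lowest number of the three, with both other compounds beyond the scatter from it. The steps of a 3.5-fold lower number from compound 1 to compound 3 (0.54 log units; beyond the scatter) and a 3.6-fold lower number from compound 2 to compound 3 (0.56 log units; beyond the scatter) both run toward the 2-aminocyclohexyl, and the step of a 1.1-fold higher number from compound 1 to compound 2 (0.02 log units; within the scatter) shows that the two open-chain groups differ little from one another.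

Compound 4 `CC(C)c1n[nH]c2c(NCc3ccc(-c4ccccn4)cc3)nc(SCCNC(N)=O)nc12` is not yet measured. It differs from compound 3 as follows: 2-ureidoethyl in place of 2-aminocyclohexyl on a sulfur. This change runs in the opposite sense to the two informative steps, moving from the ring back to an open chain, so the expectation is a rise in the number of modest size, roughly matching the steps from compounds 1 and 2 to compound 3, since compound 1 and compound 2 both sit near each other. Compound 4 is therefore expected to give about 450 nM, within 200 nM to 1000 nM, a step of a 3.2-fold higher number from compound 3 to compound 4 (0.51 log units; beyond the scatter) expected from compound 3.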

Compound 4, concentration for 50% growth inhibition: 240 nM
Estimate against measurement, compound 4: 1.9-fold (0.27 log units) above; measured number inside the range.
By their numbers in this assay, from the lowest: compounds 3, 4, 1 and 2 (each within the scatter of the next, the first and the last beyond it).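

In this assay, an open chain on the sulfur does not have to be separated from the ring: the 2-ureidoethyl group gives no step beyond the scatter from 2-aminocyclohexyl (a 1.7-fold higher number from compound 3 to compound 4 (0.24 log units; within the scatter)), so among these compounds a ring is not required for a number in this range. The open-chain groups also no longer read as one level, since compound 4 separates from compound 2 (a 2.1-fold lower number from compound 2 to compound 4 (0.32 log units; beyond the scatter)) but not from compound 1 (a 2.0-fold lower number from compound 1 to compound 4 (0.30 log units; within the scatter)). Nothing shown accounts for these steps.

Still open, going by these compounds, is whether the urea itself matters, which a plain amine or an acetamide on the same chain would test, as would a longer chain carrying the urea. Also open, on these data alone, is whether the amine of 2-aminocyclohexyl matters, which an unsubstituted cyclohexyl would test.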